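Removing a 3-methylbut-2-en-1-yl Group from Compound 2

The source may hold more compounds than are shown below. What is called first, only, known or untested is meant among the compounds shown, and "the series" means these compounds.

Compound 1 `CC(C)=CC(=O)NC(=N)N`: > 100000 nM (a limit of the assay)
Compound 2 `CC(C)=CCC/C(C)=C/CC/C(C)=C/C(=O)NC(=N)NC(=O)/C=C(\C)CC/C=C(\C)CCC=C(C)C`: 42700 nM
Compound 3 `CC(C)=CCC/C(C)=C/C(=O)NC(=N)N`: 56300 nM

The three compounds were tested in a functional assay on SK-MEL-28 cells (Homo sapiens) for inhibition, read by MTT assay, with a stated time of 72 h; on this read-out lower numbers stand for stronger inhibition of growth and higher numbers for weaker inhibition of growth. Within the data shown here, for compound 1 the value > 100000 nM is a limit of the assay rather than a number; this is the only limit among the values shown, (the limit of > 100000 nM in this assay, at which 1 of the 3 values shown sits). Compound 3 gives 56300 nM and compound 2 gives 42700 nM, two numbers that lie within the usual scatter of each other. How the cores of compound 2 and compound 3 differ is not broken down here.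

From compound 3 to compound 1 the change is hydrogen in place of 3-methylbut-2-en-1-yl on a saturated chain carbon bound to a double-bonded chain carbon, and the step is an at least 1.7-fold higher number from compound 3 to compound 1 (0.24 log units; that floor lies within the scatter). Compound 4 `CC(C)=CCC/C(C)=C/CC/C(C)=C/C(=O)NC(=N)NC(=O)/C=C(\C)CCC=C(C)C` is not yet measured; it differs from compound 2 by hydrogen in place of 3-methylbut-2-en-1-yl on a saturated chain carbon bound to a double-bonded chain carbon, the same change at the same place. The expected step of a 1.4-fold higher number from compound 2 to compound 4 (0.15 log units; within the scatter) is estimated by leaning on the earlier step of an at least 1.7-fold higher number from compound 3 to compound 1 (0.24 log units; that floor lies within the scatter), whose floor sits within the scatter, so only a modest weakening is expected. Compound 4 is therefore estimated at 60000 nM, with a range from 25000 nM to 150000 nM.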

Compound 4, concentration for 50% growth inhibition: 57300 nM
Compound 4: middle estimate off by 1.0-fold (0.02 log units), on the high side, and the stated range covers the measured number.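

In this assay, among these compounds, taking away the 3-methylbut-2-en-1-yl group gives a 1.3-fold higher number from compound 2 to compound 4 (0.13 log units; within the scatter), so on this core the change produces no step that can be told apart from the ordinary spread of repeated measurements. On the other core, compound 1 gives > 100000 nM, which is a limit of the assay and not a number. The result shows that the change is small on the core of compound 2, but it cannot establish whether the change has the same size on both cores: the same change on two cores in this assay, an at least 1.7-fold higher number (0.24 log units; that floor lies within the scatter) from compound 3 to compound 1 and a 1.3-fold higher number (0.13 log units; within the scatter) from compound 2 to compound 4; the limit leaves it open whether they differ.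

The compounds shown leave open whether an amine or a carboxylic acid in place of the 3-methylbut-2-en-1-yl group would move the number beyond the scatter. They also leave open what a longer chain at that same place would do, so the effect of the chain is described here only for the removal of this one group.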